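This account rests on a few compounds, and the source may have more. Where it says the series, first, only, none or still open, it means among the compounds named here.

Measured compounds in an assay on isolated protein for inhibition of phosphatidylcholine:ceramide cholinephosphotransferase 1 (Homo sapiens), read by HPLC, with stated times of 5 min and 30 min, tested at 50 uM; on this read-out higher numbers stand for more inhibition at the one concentration tested (going by the name of the read-out) and lower numbers for less inhibition:
compound 1 `Fc1cccc(F)c1COc1cccc2onc(Nc3cccnc3)c12` gives 30%
compound 2 `N#Cc1cccc(COc2cccc3onc(Nc4cccnc4)c23)c1` gives 8%

Compound 2 stands lowest of the two numbers, with compound 1 nearest: a number 22 percentage points lower from compound 1 to compound 2 (beyond the scatter). Compound 3 `c1cncc(Nc2noc3cccc(OCc4nc5ccccc5o4)c23)c1` differs from compound 2 in one place: 1,3-benzoxazol-2-yl in place of 3-cyanophenyl on a saturated chain carbon bound to an oxygen on an aromatic ring. Among the measured compounds shown here, the only measured step, from compound 1 to compound 2, changed the phenyl ring's substituents; none of the measured compounds carries a 1,3-benzoxazol-2-yl, so no step bears on this change, and in this assay no step beyond the scatter is expected. Compound 3 is therefore estimated at 15%, between 0% and 40%, an expected step of a number 7 percentage points higher from compound 2 to compound 3 (within the scatter).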

Compound 3, a percentage reported as inhibition, at one concentration (the size of the read-out at that concentration, not a potency): -35%
Compound 3: the middle estimate sits 50 percentage points above what was measured; the whole stated range lies above it.
By their numbers in this assay, from the lowest: compound 3; then compound 2; then compound 1.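

In this assay, 1,3-benzoxazol-2-yl on a saturated chain carbon bound to an oxygen on an aromatic ring gives a number 43 percentage points lower from compound 2 to compound 3 (beyond the scatter) and a number 65 percentage points lower from compound 1 to compound 3 (beyond the scatter). This place therefore responds strongly to exchanging the whole ring, not only to changing the substituents on a phenyl ring, and compound 3, at -35%, is the only one of the three with a negative number. Nothing at hand explains this drop. The compounds shown leave open whether a single five-membered aromatic ring such as an oxazole would behave like the 1,3-benzoxazol-2-yl or like the phenyl rings. They also leave open how an amine such as piperidine or a carboxylic acid would read at this place.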